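A few compounds are considered here, and "the series" means these few. Any claim that something is new, unique, unknown or untested is made for them only; others in the source may bear on it.

Measured compounds:
Compound 1 `Nc1cc(N)c2nc(-c3ccccc3)c(Oc3ccc(Cl)c(Cl)c3)nc2c1` gives 66100 nM in a functional assay on OVCAR-3 cells (Homo sapiens) for inhibition, read by sulforhodamine B assay, with a stated time of 48 h; on this read-out lower numbers stand for higher toxicity in this test and higher numbers for lower toxicity in this test.
Compound 2 `Nc1cc(N)c2nc(-c3ccccc3)c(NCc3ccc(Cl)c(Cl)c3)nc2c1` gives 31600 nM in this assay.
Compound 3 `Nc1cc(N)c2nc(-c3ccccc3)c(Oc3ccc(F)cc3)nc2c1` gives only a limit of the assay, < 100000 nM, in this assay.

Among the two compounds with a number in this assay, compound 2 stands lowest; its nearest neighbour is compound 1, whose number is higher by a margin beyond the scatter. Compound 3 sits at the limit (the limit of < 100000 nM in this assay, at which 1 of the 3 values shown sits), so the step that the limit leaves unreadable from compound 1 to compound 3 cannot be read.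

Compound 4 `COc1ccc(CNc2nc3cc(N)cc(N)c3nc2-c2ccccc2)cc1` differs from compound 2 by 4-methoxyphenyl in place of 3,4-dichlorophenyl on a saturated chain carbon bound to a nitrogen on an aromatic ring. Among the compounds with values here, no measured step alters the aryl on the saturated chain carbon bound to the ring nitrogen, and the only measured swap of an aryl, that from compound 1 to compound 3, stays unreadable because of the limit (the limit of < 100000 nM in this assay, at which 1 of the 3 values shown sits). The step the author estimates, a 1.4-fold higher number from compound 2 to compound 4 (0.15 log units; within the scatter), is therefore expected to be small, close to the scatter, with a modest rise considered slightly more likely than a fall. Compound 4 is accordingly estimated at 45000 nM, with a range from 15000 nM to 100000 nM.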

Compound 4, concentration lethal to 50% of the cells: 38900 nM
Compound 4: middle estimate off by 1.2-fold (0.06 log units), on the high side; measured number inside the range.
By their numbers in this assay, from the lowest: compounds 2, 4 and 1 (each within the scatter of the next, the first and the last beyond it).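

In this assay, putting 4-methoxybenzyl in place of 3,4-dichlorobenzyl gives a 1.2-fold higher number from compound 2 to compound 4 (0.09 log units; within the scatter), so this read-out does not tell the two groups apart, although they differ in chlorine, oxygen and hydrogen-bond acceptor count. Within the data shown here, this is the first readable exchange of an aryl group, and it sits on a saturated chain carbon bound to a nitrogen on an aromatic ring. The one earlier exchange of an aryl group, on an oxygen on an aromatic ring, cannot be read, since compound 3 gives only a limit: the limit of < 100000 nM in this assay, at which 1 of the 4 values shown sits.

Among these compounds, this single pair covers only two aryl groups, so it remains open whether a 4-chlorophenyl would read the same. Also open, as far as these compounds go, is how a 4-aminophenyl, a 4-carboxyphenyl or a longer chain carrying the aryl group would read at this place.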